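Swapping the aryl group on the amide-bearing carbon

The source may report more compounds than this note shows. Statements on the series, on what has been measured and on what is new or still open speak of the compounds shown alone.

Measured in an ADME assay on Vero cells (Chlorocebus sabaeus) for cytotoxicity, read by MTT assay, tested at 50 uM; a lower number here means a stronger effect, a higher number a weaker effect of the compound at the concentration tested:
Compound 1, `CCOC(=O)C(C(=O)c1ccc(OC)cc1)C(NC(C)=O)c1ccc(C(C)(C)C)cc1`, gives 92.3%.
Compound 2, `CCOC(=O)C(C(=O)c1ccc(OC)cc1)C(NC(C)=O)c1cccc2ccccc12`, gives 98.7%.
Compound 3, `CCOC(=O)C(C(=O)c1ccc(OC)cc1)C(NC(C)=O)c1ccc(OC)c(OC)c1`, gives 96.7%.

Among these three numbers compound 3 stands second highest. Its nearest neighbour is compound 2, seen in a number 2 percentage points lower from compound 2 to compound 3 (within the scatter), and its furthest is compound 1, seen in a number 4.4 percentage points higher from compound 1 to compound 3 (within the scatter).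

Compound 4, `CCOC(=O)C(C(=O)c1ccc(OC)cc1)C(NC(C)=O)c1cc(OC)ccc1Br`, has not been measured. 2-bromo-5-methoxyphenyl in place of 3,4-dimethoxyphenyl on a saturated chain carbon bound to an amide-type nitrogen and a saturated chain carbon

Every measured step changed exactly this place, and none left the scatter: a number 6.4 percentage points higher from compound 1 to compound 2 (within the scatter), a number 4.4 percentage points higher from compound 1 to compound 3 (within the scatter) and a number 2 percentage points lower from compound 2 to compound 3 (within the scatter). No step beyond the scatter is therefore expected in this assay for compound 4. The estimate for compound 4 is 95%, between 84% and 100%. This corresponds to an expected step of a number 1.7 percentage points lower from compound 3 to compound 4 (within the scatter).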

Compound 4, a percentage reported as activity, at one concentration (the size of the read-out at that concentration, not a potency): 93.3%
Compound 4: middle estimate off by 1.7 percentage points, on the high side; low and high end bracket the measured number.
By their numbers in this assay, from the lowest: compounds 1, 4, 3 and 2 (each within the scatter of the next).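

In this assay the 2-bromo-5-methoxyphenyl group gives a number 3.4 percentage points lower from compound 3 to compound 4 (within the scatter) and a number 5.4 percentage points lower from compound 2 to compound 4 (within the scatter) and a number 1 percentage points higher from compound 1 to compound 4 (within the scatter). Going by these compounds alone, this is the first aryl group here to carry a bromine, and it has one hydrogen-bond acceptor where 3,4-dimethoxyphenyl has two, yet the read-out stays within the scatter of all three earlier groups. No available evidence bears on this result. Going by these compounds, all four groups at this position are aromatic rings of carbon, so an amine, a carboxylic acid or a longer chain in their place remains open. On these data alone, whether changes elsewhere on the shared core would shift the read-out also remains open.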